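The source may hold more compounds than are shown below. What is called first, only, known or untested is meant among the compounds shown, and "the series" means these compounds.

Compound 1 `CN(C)c1ccc(C=C2C(=O)N(c3ccc(Cl)cc3)N(c3ccc(Cl)cc3)C2=O)cc1`: > 128000 nM, a limit
Compound 2 `O=C1C(=Cc2ccc(F)cc2)C(=O)N(c2ccc(Cl)cc2)N1c1ccc(Cl)cc1`: 35600 nM

For the measured compounds named here, in a functional assay on ECa-109 cells (Homo sapiens) for cytotoxicity, read by MTT assay, with a stated time of 72 h (a higher number here means a weaker inhibitor, a lower number a stronger inhibitor), compound 2 gives 35600 nM, the only actual number so far. The value of compound 1 is a limit, not a number, as the limit of > 128000 nM in this assay, at which 1 of the 2 values shown sits, records. Compound 3 `O=C1C(=Cc2ccc(Cl)cc2)C(=O)N(c2ccc(Cl)cc2)N1c1ccc(Cl)cc1` keeps the shared core and makes one change, chloro in place of fluoro on an aromatic carbon, para to a large group. Going by the values given here, only one measured step bears on this place: an at least 3.5-fold lower number from compound 1 to compound 2 (0.55 log units; beyond the scatter). That step replaced dimethylamino with fluoro and starts from a limit, so it gives only a loose guide to a change from fluoro to chloro. No shift beyond the scatter is therefore expected in this assay, and the estimated step is a 1.2-fold lower number from compound 2 to compound 3 (0.07 log units; within the scatter). For compound 3 the expected value is 30000 nM, with an estimated range from 10000 nM to 90000 nM.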

Compound 3, half-maximal inhibitory concentration: 17300 nM
Compound 3: the middle estimate sits 1.7-fold (0.24 log units) above what was measured; low and high end bracket the measured number.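

For the compounds shown here, at this place, on an aromatic carbon para to a large group, the choice between two halogens proves to matter in this assay: chloro in place of fluoro gives a 2.1-fold lower number from compound 2 to compound 3 (0.31 log units; beyond the scatter), a modest step beyond the scatter, whereas the earlier compounds showed only a change away from dimethylamino. Chloro in place of dimethylamino gives an at least 7.3-fold lower number from compound 1 to compound 3 (0.86 log units; beyond the scatter), so chloro too can now be set against dimethylamino at this place. The value of compound 1 is a limit, not a number: the limit of > 128000 nM in this assay, at which 1 of the 3 values shown sits.

The compounds shown carry only fluoro, chloro and dimethylamino at this place, so whether bromo, methoxy or a carboxylic acid would give a lower or higher number stays open. Why chloro gives the lower number also stays open: no measured property of either group is shown.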